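Fluoroindole placement on amine-linked and amide-linked hydroxamates

A few compounds are considered here, and "the series" means these few. Any claim that something is new, unique, unknown or untested is made for them only; others in the source may bear on it.

Compound 2 `O=C(COc1ccc(CNC2CC=C(c3c[nH]c4ccc(F)cc34)CC2)c(F)c1)NO` and compound 1 `O=C(COc1ccc(CNC2CC=C(c3c[nH]c4cccc(F)c34)CC2)c(F)c1)NO` share one core and differ by 4-fluoro-1H-indol-3-yl in place of 5-fluoro-1H-indol-3-yl on a double-bonded ring carbon. In a functional assay on SW480 cells (Homo sapiens) for antiproliferative activity, with a stated time of 72 h (a higher number here means a weaker inhibitor, a lower number a stronger inhibitor), compound 2 gives 179 nM, and compound 1 gives 189 nM; the step is a 1.1-fold higher number from compound 2 to compound 1 (0.02 log units; within the scatter). Compound 3 `O=C(COc1ccc(C(=O)N2CC=C(c3c[nH]c4ccc(F)cc34)CC2)cc1)NO` carries a different core; the difference between the cores of compound 2 and compound 3 is not broken down here. In this assay compound 3 gives only a limit, > 5000 nM. Compound 4 `O=C(COc1ccc(C(=O)N2CC=C(c3c[nH]c4cccc(F)c34)CC2)cc1)NO` is compound 3 with 4-fluoro-1H-indol-3-yl in place of 5-fluoro-1H-indol-3-yl on a double-bonded ring carbon; here the ring bearing the group is a six-membered non-aromatic ring with 1 nitrogen, three ring bonds from the ring nitrogen, rather than a ring of carbon only, so this is the same kind of change, not the same. Beside a 1.1-fold higher number from compound 2 to compound 1 (0.02 log units; within the scatter), the expected step is a step that the limit leaves unreadable from compound 3 to compound 4, resting on compound 3 sitting at the limit of > 5000 nM in this assay, at which 1 of the 3 values shown sits. Compound 4 is therefore estimated at 8000 nM in this assay.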

Compound 4, half-maximal inhibitory concentration: 1490 nM
Estimate against measurement, compound 4: 5.4-fold (0.73 log units) above; measured number below the stated range.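

In this assay the swap of 5-fluoro-1H-indol-3-yl for 4-fluoro-1H-indol-3-yl gives an at least 3.3-fold lower number from compound 3 to compound 4 (0.52 log units; beyond the scatter) and so does not carry over unchanged from one core to the other: the same change on two cores in this assay, a 1.1-fold higher number (0.02 log units; within the scatter) from compound 2 to compound 1 and an at least 3.3-fold lower number (0.52 log units; beyond the scatter) from compound 3 to compound 4, at least 3.5-fold (0.54 log units) apart, beyond the scatter of two such steps. Compound 3 holds only a limit, so the step from it has a bound and no exact size: the limit of > 5000 nM in this assay, at which 1 of the 4 values shown sits. With a single pair on each core, this shows that the outcome of the swap differed between these two cores, but not which part of the core difference is responsible or how the swap would behave on any further core.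

Still open, on these data alone, is whether the same gap would appear with 6-fluoro-1H-indol-3-yl or 4-chloro-1H-indol-3-yl on both cores.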